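A few compounds are considered here, and "the series" means these few. Any claim that something is new, unique, unknown or untested is made for them only; others in the source may bear on it.

Compound 1 `COc1ccc(CNc2nc([Se]C)nc3ccccc23)cc1` carries a methoxy group on an aromatic carbon of its outer ring and, on the shared core, a group made of one carbon and one selenium atom. In a functional assay on MCF7 cells (Homo sapiens) for cytotoxicity, read by MTT assay, with a stated time of 72 h (on this read-out higher numbers stand for weaker inhibition of growth and lower numbers for stronger inhibition of growth), compound 1 gives 98600 nM, the highest of the two plain numbers in this small set. Compound 2 `C[Se]c1nc(NCc2ccccc2)c2ccccc2n1` has hydrogen in place of that methoxy and in this assay gives 67000 nM; the step of a 1.5-fold lower number from compound 1 to compound 2 (0.17 log units; within the scatter). Compound 3 `CSc1ccc(CNc2nc([Se]C)nc3ccccc23)cc1` carries methylsulfanyl in place of the methoxy. For compound 3 this assay reports only a limit, > 100000 nM, which is the limit of > 100000 nM in this assay, at which 1 of the 3 values shown sits. Accordingly the step of an at least 1.0-fold higher number from compound 1 to compound 3 (0.00 log units; that floor lies within the scatter) and the step of an at least 1.4-fold higher number from compound 2 to compound 3 (0.17 log units; that floor lies within the scatter) are floors that stay within the scatter.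

Compound 4 `COc1ccc(CNc2nc(S)nc3ccccc23)cc1` differs from compound 1 at the core rather than at the outer ring: one sulfur atom in place of a group of 2 heavy atoms (1 carbon, 1 selenium; no ring), on an aromatic carbon. For the measured compounds named here, none of the measured steps touches this group; all three alter only the substituent on the outer ring, and all three stay within the scatter. Going by the values given here, there is thus no measured step that bears directly on the change, and no direction can be read from the data. In the absence of such a guide the number for compound 4 is expected to lie near that of compound 1, at an estimated 100000 nM with a range from 30000 nM to 300000 nM. This estimate corresponds to the expected step of a 1.0-fold higher number from compound 1 to compound 4 (0.01 log units; within the scatter), which would stay within the scatter.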

Compound 4, concentration for total growth inhibition: 36500 nM
The estimate for compound 4 lay 2.7-fold (0.44 log units) above the measured number, within the range that was stated.
By their numbers in this assay, from the lowest: compounds 4, 2 and 1 (each within the scatter of the next, the first and the last beyond it). At a limit, above all of these: compound 3.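

Moving the change from the outer ring to the shared core produces the only step in this set that lies beyond the scatter: in this assay, replacing the group of one carbon and one selenium with sulfanyl gives a 2.7-fold lower number from compound 1 to compound 4 (0.43 log units; beyond the scatter), a modest move towards stronger inhibition of growth. For the compounds shown here, this shows that the position on the core, between two ring nitrogen atoms, can change the read-out, though this rests on a single pair of compounds, whereas no step on the outer ring has gone beyond the scatter. Sulfanyl counts as a hydrogen-bond donor and acceptor and the departing group as neither, but nothing measured here says what lies behind the step.

The step swaps selenium for sulfur and removes the carbon at once, so the two changes cannot be told apart; a methylsulfanyl group or an amine at this core position would help to separate them. From the compounds shown here alone, it also remains open whether sulfanyl on the core gives a similar step when the outer ring carries hydrogen or methylsulfanyl instead of methoxy.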